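The source may hold more compounds than are shown below. What is called first, only, known or untested is meant among the compounds shown, and "the series" means these compounds.

Measured so far:
compound 1 `CC(NC(=O)/C=C/Oc1ccc(NC(=O)Nc2cc(C(F)(F)F)ccc2Cl)cc1)c1ccccc1` — 16400 nM
compound 2 `CNC(=O)C#Cc1ccc(NC(=O)Nc2ccc(Cl)c(C(F)(F)F)c2)cc1` — 24700 nM
compound 3 `CC(NC(=O)c1cccc(-c2ccc(NC(=O)Nc3ccc(Cl)c(C(F)(F)F)c3)cc2)c1)c1ccccc1` — 6460 nM

In a functional assay on KETR3 cells (Homo sapiens) for inhibition, read by MTT assay, with a stated time of 120 h (a higher number here means a weaker inhibitor, a lower number a stronger inhibitor), compound 2 stands at the highest of the three numbers. Compound 1 lies within the scatter of compound 2, while compound 3 lies beyond it at the lower end. Compound 4 `O=C(CCc1ccc(NC(=O)Nc2ccc(Cl)c(C(F)(F)F)c2)cc1)NC1CCC1` is not yet measured and differs from compound 2 in one place: 2-(cyclobutylcarbamoyl)ethyl in place of 2-(methylcarbamoyl)ethynyl on an aromatic carbon. The triple bond goes and a four-membered ring comes in, para to a large group. Going by the values given here, no step between measured compounds that differ in one place is available. Among the compounds with values here, the lower number of compound 3 with its larger group is the only guide, so a modest step down is expected in this assay, a 2.1-fold lower number from compound 2 to compound 4 (0.31 log units; beyond the scatter). For compound 4 the estimate is 12000 nM, with a range of 4000 nM to 36000 nM.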

Compound 4, half-maximal inhibitory concentration: > 50000 nM
Compound 4 was reported as a limit; the forecaster's own chance of this, stated with the estimate: 10%; middle value at least 4.1-fold (0.61 log units) from the limit.
By their numbers in this assay, from the lowest: compound 3; then compounds 1 and 2 (each within the scatter of the next). At a limit, above all of these: compound 4.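

In this assay compound 4 is reported only as a limit, > 50000 nM. Replacing 2-(methylcarbamoyl)ethynyl with 2-(cyclobutylcarbamoyl)ethyl on this aromatic carbon gives an at least 2.0-fold higher number from compound 2 to compound 4 (0.30 log units; that floor lies within the scatter), which fixes a floor and not a size for the step. This first one-place reading at the position shows no lower number with the larger group: the limit of > 50000 nM in this assay, at which 1 of the 4 values shown sits.

The compounds shown do not separate the departure of the triple bond from the entry of the cyclobutyl ring. A 2-(methylcarbamoyl)ethyl group or a 2-(cyclobutylcarbamoyl)ethynyl group at this place would separate the two.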